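This account rests on a few compounds, and the source may have more. Where it says the series, first, only, none or still open, it means among the compounds named here.

Compounds measured so far:
compound 1, `CCCCCCCCNC(=O)[C@@H]1CSC(c2cc(OC)c(OC)c(OC)c2)N1`: 19600 nM
compound 2, `CCCCCCCCCCCCCCCNC(=O)[C@@H]1CSC(c2ccc(NC(C)=O)cc2)N1`: 1000 nM

In a functional assay on WM164 cells (Homo sapiens) for antiproliferative activity, read by sulforhodamine B assay, with a stated time of 48 h (a lower number here means a stronger inhibitor, a higher number a weaker inhibitor), compound 2 gives the lower of the two numbers; compound 1 gives a value that is a large gap higher, well beyond the scatter. Compound 3, `CCCCCCCCCCCCCCCCCCNC(=O)[C@@H]1CSC(c2ccc(NC(C)=O)cc2)N1`, is not yet measured. It differs from compound 2 by propyl in place of hydrogen on a saturated chain carbon, ten or more bonds along the chain from an amide-type nitrogen. Within the data shown here, no measured pair separates this change on its own, so its effect is unknown from these data. Compound 3 is expected to come close to compound 2, with a step of no change at the digits printed from compound 2 to compound 3 (within the scatter) that stays within the scatter, and an estimated value of 1000 nM, between 300 nM and 3500 nM.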

Compound 3, half-maximal inhibitory concentration: 11600 nM
Compound 3: middle estimate off by 12-fold (1.06 log units), on the low side; measured number outside the range, above it.
By their numbers in this assay, from the lowest: compound 2; then compounds 3 and 1 (each within the scatter of the next).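

In this assay, propyl in place of hydrogen on a saturated chain carbon, ten or more bonds along the chain from an amide-type nitrogen, gives a 12-fold higher number from compound 2 to compound 3 (1.06 log units; beyond the scatter), a large step toward weaker inhibition. Among these compounds, this place on the chain is therefore not neutral to change, which the earlier compounds, forming no pair that differs in one place, could not show. Nothing given here accounts for the step. The compounds shown leave open how a shorter chain would read in this assay, and whether an amine or a carboxylic acid at this place would keep the activity of compound 2.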